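A bigger swap on a saturated ring carbon

A few compounds are considered here, and "the series" means these few. Any claim that something is new, unique, unknown or untested is made for them only; others in the source may bear on it.

Compound 1 `O=S1(=O)CC(c2ccc(F)cc2)c2c(C3CC3)nn(-c3ccccc3F)c2O1` gives 1.76
Compound 2 `O=S1(=O)CC(c2ccc(F)cc2)c2c(C3CC3)nn(-c3ccccc3Cl)c2O1` gives 2.04

Among the compounds with values here, both numbers come from a physicochemical assay for lipophilicity, using the shake flask method, in phosphate buffer, measured as octanol-water partition, with a stated time of 24 h, at pH 7.4 (on this read-out higher numbers stand for higher lipophilicity and lower numbers for lower lipophilicity), and lie within the usual scatter of each other, so compound 1 cannot be placed clearly on either side of its one measured neighbour. Compound 3 `Cc1cc(C2CS(=O)(=O)Oc3c2c(C2CC2)nn3-c2ccccc2F)ccc1Br` differs from compound 1 as follows: 4-bromo-3-methylphenyl in place of 4-fluorophenyl on a saturated ring carbon and so carries 4-bromo-3-methylphenyl in place of 4-fluorophenyl on a saturated ring carbon. Within the data shown here, only one measured step bears on this, a number 0.28 log units higher from compound 1 to compound 2 (within the scatter) for chloro in place of fluoro on an aromatic carbon. That swap sits elsewhere in the molecule and changes less, since here bromine replaces fluorine and a methyl is added. A step to higher numbers is therefore expected in this assay and is estimated as a number 1.04 log units higher from compound 1 to compound 3 (beyond the scatter) with real uncertainty. The estimated value for compound 3 is 2.8 and the expected range runs (2.3 to 3.3).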

Compound 3, partition coefficient: 2.72
The estimate for compound 3 lay 0.08 log units above the measured number; low and high end bracket the measured number.
By their numbers in this assay, from the lowest: compounds 1 and 2 (each within the scatter of the next); then compound 3.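

On the saturated ring carbon, 4-bromo-3-methylphenyl in place of 4-fluorophenyl gives, in this assay, a number 0.96 log units higher from compound 1 to compound 3 (beyond the scatter) and so clearly moves the number. Within the data shown here, the only earlier step, a number 0.28 log units higher from compound 1 to compound 2 (within the scatter), did not do so, which makes this the first sign that a change in this set can shift the read-out beyond the usual scatter. Nothing measured here gives a reason for this shift.

The swap adds a methyl and exchanges fluorine for bromine at once, and no compound shown has 4-bromophenyl or 3-methylphenyl here, so the share of each remains open. Also open, as far as these compounds go, is how the read-out would respond at this position to a phenyl ring carrying an amine or a carboxylic acid.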